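From 4-Chlorophenyl to Pyrazin-2-yl on a Ring Amine

A few compounds are considered here, and "the series" means these few. Any claim that something is new, unique, unknown or untested is made for them only; others in the source may bear on it.

Compound 1 `Nc1ccccc1NC(=O)c1ccc(CSC(=S)N2CCN(c3ccc(Cl)cc3)CC2)cc1`: 32.2%
Compound 2 `CN(Cc1cccnc1)C(=S)SCc1ccc(C(=O)Nc2ccccc2N)cc1`: 39.4%

In a functional assay on A-375 cells (Homo sapiens) for antiproliferative activity, read by CCK-8 assay, with a stated time of 72 h, tested at 2 uM (on this read-out lower numbers stand for a weaker effect and higher numbers for a stronger effect at the one concentration tested), compound 1 gives 32.2%, the lower of the two numbers measured. Compound 2 gives 39.4%, a number within the usual scatter of compound 1, so the two cannot be ranked. Compound 3 `Nc1ccccc1NC(=O)c1ccc(CSC(=S)N2CCN(c3cnccn3)CC2)cc1` is not yet measured; it differs from compound 1 in one place: pyrazin-2-yl in place of 4-chlorophenyl on an amine nitrogen in a ring. Among the measured compounds shown here, no step between two measured compounds is known, and the two values do not separate. The step expected is a number 0.2 percentage points lower from compound 1 to compound 3 (within the scatter), not beyond the scatter in either direction. Compound 3 is estimated at 32%, within the range 14% to 52%.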

Compound 3, a percentage reported as inhibition, at one concentration (the size of the read-out at that concentration, not a potency): 29.1%
The estimate for compound 3 lay 2.9 percentage points above the measured number, and the stated range covers the measured number.
By their numbers in this assay, from the lowest: compounds 3, 1 and 2 (each within the scatter of the next, the first and the last beyond it).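

In this assay, the step at this position, a number 3.1 percentage points lower from compound 1 to compound 3 (within the scatter), lies within the scatter, so pyrazin-2-yl and 4-chlorophenyl on the amine nitrogen in the ring cannot be told apart. An aromatic ring of carbon only and one with 2 hetero atoms thus give numbers that do not separate at the one concentration tested. No evidence at hand bears on this result. The compounds shown leave open whether a non-aromatic group on this nitrogen, such as cyclohexyl or a plain methyl, would stay within the scatter of compound 1.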